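Methyl on the ring carbon: one change in two settings

The compounds below may be only part of what the source reports. "The series", "measured", "known", "first", "only" and "open" are said of these compounds alone.

Compound 1 `CCOC(=O)N(C)C(C)C#CCn1ccnc1` and compound 2 `CCOC(=O)N(C)C(C)C#CCn1cncc1C` share a core and differ in one place, (methyl in place of hydrogen on an aromatic carbon). In a functional assay on the whole organism for antagonist activity, with Mus musculus as the target (a lower number here means that less compound is needed, a higher number that more compound is needed for the effect), compound 1 gives 66 mg/kg, and compound 2 gives 17.3 mg/kg, a step of a 3.8-fold lower number from compound 1 to compound 2 (0.58 log units; beyond the scatter). Compound 3 `CN1CCN(CC#CCn2ccnc2)C1=O` has a different core; the difference between the two cores is not broken down here. For compound 3 in this assay only a limit is known, > 100 mg/kg, and the limit of > 100 mg/kg in this assay, at which 1 of the 3 values shown sits, marks that boundary. Compound 4 `Cc1cncn1CC#CCN1CCN(C)C1=O` carries the same change on the core of compound 3, (methyl in place of hydrogen on an aromatic carbon). Compound 4 is expected to sit at 60 mg/kg, with a range from 20 mg/kg to 200 mg/kg. The step for compound 4 is expected to be an at least 1.6-fold lower number from compound 3 to compound 4 (0.22 log units; that floor lies within the scatter), resting on the measured step from compound 1 to compound 2, a 3.8-fold lower number from compound 1 to compound 2 (0.58 log units; beyond the scatter), though the starting value of compound 3 is only a limit.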

Compound 4, dose for half-maximal effect: > 100 mg/kg
Compound 4 was reported as a limit; the forecaster's own chance of this, stated with the estimate: 45%; middle value at least 1.6-fold (0.22 log units) away from the limit.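

Compound 3 and compound 4 both stop at the same limit of the assay, so no step between them can be read: the limit of > 100 mg/kg in this assay, at which 2 of the 4 values shown sit.

Still open, going by these compounds, is whether methyl in place of hydrogen changes the needed dose on the core of compound 3, as it does on the core of compound 1.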